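This account rests on a few compounds, and the source may have more. Where it says the series, first, only, none or still open, it means among the compounds named here.

Measured in a functional assay on HeLa S3 cells (Homo sapiens) for antiproliferative activity, read by XTT assay, with a stated time of 72 h; a higher number here means a weaker inhibitor, a lower number a stronger inhibitor:
- compound 1 `CSc1ncnc2c1c(-c1ccsc1)cn2[C@@H]1O[C@H](CO)[C@@H](O)[C@H]1O`: > 20000 nM, a limit
- compound 2 `CNc1ncnc2c1c(-c1ccsc1)cn2[C@@H]1O[C@H](CO)[C@@H](O)[C@H]1O`: > 20000 nM, a limit
- compound 3 `Cc1ncnc2c1c(-c1ccsc1)cn2[C@@H]1O[C@H](CO)[C@@H](O)[C@H]1O`: 14300 nM

Among the compounds with values here, compound 3 gives the only actual number in this short series, while the other two compounds rest on (the limit of > 20000 nM in this assay, at which 2 of the 3 values shown sit). The next compound, compound 4 `Cc1ncnc2c1c(I)cn2[C@@H]1O[C@H](CO)[C@@H](O)[C@H]1O`, keeps the methyl group of compound 3 and has iodo in place of thiophen-3-yl on an aromatic carbon of a five-membered aromatic ring with 1 nitrogen: iodo in place of thiophen-3-yl on an aromatic carbon.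

The measured steps offer only indirect guidance. They are a step that the two limits leave unreadable from compound 1 to compound 2, an at least 1.3-fold lower number from compound 1 to compound 3 (0.14 log units; that floor lies within the scatter) and an at least 1.3-fold lower number from compound 2 to compound 3 (0.14 log units; that floor lies within the scatter). Within the data shown here, all three change the group on another carbon, and none touches the carbon that carries the thiophen-3-yl, so no measured step shows what replacing that group does. All three compounds carry thiophen-3-yl, and even compound 3 reaches only 14300 nM, so a lower number in this assay is expected, though with little confidence. A reading at the limit also remains possible. The expected change is a 2.9-fold lower number from compound 3 to compound 4 (0.46 log units; beyond the scatter). Compound 4 is estimated at 5000 nM, with an expected range of 400 nM to 20000 nM.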

Compound 4, half-maximal inhibitory concentration: 4080 nM
Beside the measured number, compound 4's estimate is 1.2-fold (0.09 log units) above it; the measured number falls inside the stated range.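

In this assay, within the data shown here, putting iodo in place of thiophen-3-yl gives a 3.5-fold lower number from compound 3 to compound 4 (0.54 log units; beyond the scatter), the first measured change at this carbon of the five-membered aromatic ring with 1 nitrogen. The earlier compounds shown here all carried thiophen-3-yl here, so they could not show that this position affects the read-out, or that a group with no ring at all can stand on this carbon and still give a lower number than compound 3. This comparison also has actual numbers on both sides, whereas the earlier series rests largely on a limit: the limit of > 20000 nM in this assay, at which 2 of the 4 values shown sit.

One pair cannot tell whether the lower number follows from losing the thiophen-3-yl ring or from the iodine itself, and a bromo, ethynyl or phenyl group on this carbon would begin to separate the two. The iodo group is shown only with the methyl group of compound 3, so it remains open whether it would give a comparable step alongside the methylsulfanyl group of compound 1 or the methylamino group of compound 2.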